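From 4-methoxyphenyl to furan-2-yl on a shared core

The source may report more compounds than this note shows. Statements on the series, on what has been measured and on what is new or still open speak of the compounds shown alone.

In a functional assay on microsomes for inhibition, with a stated time of 1 h (on this read-out lower numbers stand for stronger inhibition and higher numbers for weaker inhibition), compound 1 `CCOC(=O)c1cnn(-c2nc(-c3ccc(OC)cc3)c(C#N)c(=O)n2C)c1N` gives 68 ug/mL. This cannot be told apart from compound 2 `CSc1nc(-c2cccs2)c(C#N)c(=O)n1C` at 83 ug/mL or from compound 3 `CSc1nc(-c2ccccc2O)c(C#N)c(=O)n1C` at 44 ug/mL, since all three numbers lie within the usual scatter of one another. Compound 4 `CCOC(=O)c1cnn(-c2nc(-c3ccco3)c(C#N)c(=O)n2C)c1N` keeps the core of compound 1 but carries furan-2-yl in place of 4-methoxyphenyl on an aromatic carbon. For the measured compounds named here, no two measured compounds differ in just one place, so the data give no direct guide to the size of such a change. The closeness of the three numbers suggests no step beyond the scatter in either direction. The expected step runs a 1.1-fold lower number from compound 1 to compound 4 (0.04 log units; within the scatter). Compound 4 is estimated at 62 ug/mL, with an expected range from 28 ug/mL to 135 ug/mL.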

Compound 4, half-maximal inhibitory concentration: 116 ug/mL
Compound 4: middle estimate off by 1.9-fold (0.27 log units), on the low side; the range from low to high includes it.
By their numbers in this assay, from the lowest: compounds 3, 1, 2 and 4 (each within the scatter of the next, the first and the last beyond it).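

In this assay, furan-2-yl in place of 4-methoxyphenyl gives a 1.7-fold higher number from compound 1 to compound 4 (0.23 log units; within the scatter). For the compounds shown here, this is the first direct reading at this position: on the shared core, a five-membered aromatic ring with one hetero atom and a six-membered carbon ring cannot be told apart here. No supporting measurement accounts for the result. Going by these compounds, it remains open whether an amine or a carboxylic acid on this aromatic carbon would move the number beyond the scatter. Also open, on these data alone, is whether furan-2-yl would read the same with other neighbouring groups on the core.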